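A few compounds are considered here, and "the series" means these few. Any claim that something is new, unique, unknown or untested is made for them only; others in the source may bear on it.

Compound 1 `Cc1nc(O)c(C#N)c(NCc2ccccn2)n1`: 43000 nM
Compound 2 `CCc1nc(O)c(C#N)c(NCc2cccnc2)n1`: 5500 nM

In a functional assay (muscle tissue) with Felis catus as the target (on this read-out lower numbers stand for an effect already at smaller amounts and higher numbers for an effect only at larger amounts of compound), compound 1 gives 43000 nM, and compound 2 gives 5500 nM. Compound 2 therefore holds the lower of the two numbers, and the gap between them lies beyond the usual scatter. These two compounds are not related by a change in one place, so their gap cannot be pinned on any single group.

Compound 3 `N#Cc1c(O)nc(Cc2ccccc2)nc1NCc1cccnc1` comes from compound 2 through one change: phenyl in place of methyl on a saturated chain carbon bound to an aromatic carbon. This puts phenyl in place of methyl on a saturated chain carbon bound to an aromatic carbon, turning ethyl into benzyl. For the measured compounds named here, no measured pair shows what such a change does, so the expectation is loose. In this assay a modest step toward a lower number is expected, and it may not clear the scatter. The estimated step is a 1.8-fold lower number from compound 2 to compound 3 (0.26 log units; within the scatter). For compound 3 the expected value is 3000 nM, with an estimated range of 500 nM to 20000 nM.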

Compound 3, half-maximal effective concentration: 72000 nM
Estimate against measurement, compound 3: 24-fold (1.38 log units) below; the measured number lies above the stated range.
By their numbers in this assay, from the lowest: compound 2; then compounds 1 and 3 (each within the scatter of the next).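

In this assay, for the compounds shown here, this is the first measured change at this position: turning ethyl into benzyl, with phenyl in place of methyl on a saturated chain carbon bound to an aromatic carbon, gives a large step, a 13-fold higher number from compound 2 to compound 3 (1.12 log units; beyond the scatter). The position is therefore not indifferent to what stands on it, and in this one pair the added phenyl ring goes with an effect only at larger amounts of compound. Nothing available explains why the number rises so far.

A single pair cannot separate the effect of the phenyl ring from that of simply having more atoms at this place. A propyl chain, or a chain ending in an amine, on the same carbon would help show which of the two goes with the rise.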